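Sulfonyl aryl swap in the nitroindole hydrazone series

A few compounds are considered here, and "the series" means these few. Any claim that something is new, unique, unknown or untested is made for them only; others in the source may bear on it.

Compound 3 `COc1ccc(S(=O)(=O)n2cc(/C=N/N=C/N(C)C)c3c([N+](=O)[O-])cccc32)cc1` gives 740 nM in a functional assay on HEK293 cells for inhibition of 5-hydroxytryptamine receptor 6 (Homo sapiens), read by calcium flux and cAMP accumulation, with a stated time of 10 min (on this read-out higher numbers stand for weaker inhibition and lower numbers for stronger inhibition), and stands lowest of the three numbers measured. Compound 2 `Cc1ccc(S(=O)(=O)n2cc(/C=N/N=C/N(C)C)c3c([N+](=O)[O-])cccc32)cc1` gives 2120 nM and compound 1 `CN(C)/C=N/N=C/c1cn(S(=O)(=O)c2ccc(F)cc2)c2cccc([N+](=O)[O-])c12` gives 4970 nM. The steps of a 6.7-fold lower number from compound 1 to compound 3 (0.83 log units; beyond the scatter) and a 2.9-fold lower number from compound 2 to compound 3 (0.46 log units; beyond the scatter) both lie beyond the scatter, as does a 2.3-fold lower number from compound 1 to compound 2 (0.37 log units; beyond the scatter); all three change only the single substituent on the phenyl ring attached to the sulfonyl sulfur.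

Compound 4 `CN(C)/C=N/N=C/c1cn(S(=O)(=O)c2cccc3ccccc23)c2cccc([N+](=O)[O-])c12` differs from compound 3 by naphthalen-1-yl in place of 4-methoxyphenyl on a sulfonyl sulfur. Within the data shown here, none of the measured steps replaces the ring itself, so no step bears directly on this change; the closest precedent is that the methoxy-bearing ring gives the lowest number and the fluoro-bearing ring the highest, with the methyl-bearing ring between them. With no direct guide, compound 4 is expected to give a number somewhat higher than compound 3, of the order of a 2.0-fold higher number from compound 3 to compound 4 (0.31 log units; beyond the scatter), though a result within the scatter of compound 3 cannot be excluded. The estimate for compound 4 is 1500 nM, with a range from 400 nM to 6000 nM.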

Compound 4, half-maximal inhibitory concentration: 2960 nM
Compound 4: middle estimate off by 2.0-fold (0.30 log units), on the low side; measured number inside the range.
By their numbers in this assay, from the lowest: compound 3; then compounds 2, 4 and 1 (each within the scatter of the next, the first and the last beyond it).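

In this assay, these notes now cover a change of the ring itself on the sulfonyl sulfur, not only of its substituent, and against the 4-methoxyphenyl ring naphthalen-1-yl gives a 4.0-fold higher number from compound 3 to compound 4 (0.60 log units; beyond the scatter). Against the other two rings the change is not resolved, with a 1.4-fold higher number from compound 2 to compound 4 (0.14 log units; within the scatter) and a 1.7-fold lower number from compound 1 to compound 4 (0.23 log units; within the scatter), so a second aromatic ring at this position matches compound 2 and compound 1 within the scatter but not compound 3. No supporting evidence bears on this result.

Open, going by these compounds, is whether a longer alkoxy chain such as ethoxy, or an amine such as dimethylamino, in place of methoxy on the phenyl ring would match compound 3. Also open, on these data alone, is whether a methoxy group on the naphthalen-1-yl ring would shift the number of compound 4.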